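This account rests on a few compounds, and the source may have more. Where it says the series, first, only, none or still open, it means among the compounds named here.

Measured so far in a functional assay on MCF7 cells (Homo sapiens) for inhibition, read by CCK-8 assay, with a stated time of 48 h; a lower number here means a stronger inhibitor, a higher number a weaker inhibitor:
compound 1 `COc1ccc(-c2cc3nccc(-c4cc(OC)c(OC)c(OC)c4)n3n2)cc1N` — 27 nM
compound 2 `COc1cc(-c2ccnc3cc(-c4ccc(C(C)(C)C)cc4)nn23)cc(OC)c1OC` — the assay reports only a limit for compound 2, > 10000 nM
compound 3 `COc1cc(-c2ccnc3cc(-c4ccc(C(C)=O)cc4)nn23)cc(OC)c1OC` — 5230 nM

Compound 3 stands at the highest of the two numbers in this assay. Its nearest neighbour is compound 1: a 190-fold higher number from compound 1 to compound 3 (2.29 log units; beyond the scatter). Compound 2 sits at the floor of what the assay resolves, (the limit of > 10000 nM in this assay, at which 1 of the 3 values shown sits). Between the two weak compounds the difference is small: an at least 1.9-fold lower number from compound 2 to compound 3 (0.28 log units; that floor lies within the scatter). Both large steps in the set concern the same place on the shared core, where an aryl group replaces the 3-amino-4-methoxyphenyl of compound 1: an at least 370-fold higher number from compound 1 to compound 2 (2.56 log units; beyond the scatter) and a 190-fold higher number from compound 1 to compound 3 (2.29 log units; beyond the scatter).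

Compound 4 `COc1ccc(-c2cc3nccc(-c4cc(OC)c(OC)c(OC)c4)n3n2)cc1F` differs from compound 3 in exactly that place: 3-fluoro-4-methoxyphenyl in place of 4-acetylphenyl on an aromatic carbon. The entering 3-fluoro-4-methoxyphenyl keeps the methoxy of compound 1 and carries fluorine where compound 1 carries the amino group, so compound 4 stands far closer to compound 1 than compound 3 does. The step from compound 1 to compound 3 was large upward; running the change back toward an aryl group of that kind, a large downward step is expected for compound 4 in this assay, a 65-fold lower number from compound 3 to compound 4 (1.82 log units; beyond the scatter). The estimate for compound 4 is 80 nM, within 20 nM to 400 nM.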

Compound 4, half-maximal inhibitory concentration: 183 nM
Beside the measured number, compound 4's estimate is 2.3-fold (0.36 log units) below it; low and high end bracket the measured number.
By their numbers in this assay, from the lowest: compound 1; then compound 4; then compound 3. At a limit, above all of these: compound 2.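

In this assay, the amino group of compound 1 is not needed to keep this place on the shared core far from the weak end of the series: the 3-fluoro-4-methoxyphenyl, which has no amino group, gives a 29-fold lower number from compound 3 to compound 4 (1.46 log units; beyond the scatter). The step from the 4-(tert-butyl)phenyl compound is an at least 54-fold lower number from compound 2 to compound 4 (1.73 log units; beyond the scatter), and it is only a bound, with compound 2 standing at a limit and not at a number: the limit of > 10000 nM in this assay, at which 1 of the 4 values shown sits. The amino group still counts for something, though a single-group change costs far less here than the change of the whole aryl group did, with a 6.8-fold higher number from compound 1 to compound 4 (0.83 log units; beyond the scatter) for fluoro in place of amino on an otherwise identical aryl group.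

The compounds shown do not separate what the methoxy and the fluoro each contribute, as both arrive together on the entering aryl group, and no cause for any of these steps can be read from the data. From the compounds shown here alone, whether a hydroxyl or a dimethylamino in the place of the fluoro would fall nearer compound 1 or nearer compound 4 remains open.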